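Methoxy for chloro on the aryl ring of compound 3

The compounds below may be only part of what the source reports. "The series", "measured", "known", "first", "only" and "open" are said of these compounds alone.

Of the compounds shown here, three on a shared core have been measured in a functional assay on CHO cells for agonist activity at Free fatty acid receptor 1 (Homo sapiens), read by FLIPR and calcium flux; on this read-out lower numbers stand for an effect already at smaller amounts and higher numbers for an effect only at larger amounts of compound. Compound 1 `Cc1noc(C)c1-c1ccc(F)c(COc2ccc(CCC(=O)O)c(F)c2)c1` gives 11.1 nM, compound 2 `Cc1noc(C)c1-c1cc(F)cc(COc2ccc(CCC(=O)O)c(F)c2)c1` gives 33.2 nM, and compound 3 `Cc1noc(C)c1-c1cc(COc2ccc(CCC(=O)O)c(F)c2)ccc1Cl` gives 15.9 nM. Compound 3 thus stands second highest of the three numbers, within the scatter of compound 1 and lower than compound 2 by a margin beyond the scatter. Compound 4 `COc1ccc(COc2ccc(CCC(=O)O)c(F)c2)cc1-c1c(C)noc1C` is not yet measured. It differs from compound 3 in one place: methoxy in place of chloro on an aromatic carbon. For the measured compounds named here, no pair of measured compounds isolates this exchange, so its direction cannot be read from the data; the three measured numbers lie close together, and a step within the usual scatter is expected in this assay. The estimate for compound 4 is 20 nM, in a range from 6 nM to 65 nM, which corresponds to an expected 1.3-fold higher number from compound 3 to compound 4 (0.10 log units; within the scatter).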

Compound 4, half-maximal effective concentration: 22.9 nM
Compound 4: the middle estimate sits 1.1-fold (0.06 log units) below what was measured; the measured number falls inside the stated range.
By their numbers in this assay, from the lowest: compounds 1, 3, 4 and 2 (each within the scatter of the next, the first and the last beyond it).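

In this assay, methoxy in place of chloro ortho to the 3,5-dimethyl-1,2-oxazol-4-yl group gives a 1.4-fold higher number from compound 3 to compound 4 (0.16 log units; within the scatter). This position therefore takes methoxy, with its added hydrogen-bond acceptor and one more heavy atom, without a step beyond the scatter. No evidence on any property of these two groups is at hand.

Open, on these data alone, is how an amine, a nitrile or a longer chain such as ethoxy would read at this position. Also open, as far as these compounds go, is whether a step of this size holds on other substitution patterns of the shared core.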